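A few compounds are considered here, and "the series" means these few. Any claim that something is new, unique, unknown or untested is made for them only; others in the source may bear on it.

Compound 1 `C/N=C(\S)CCn1nc(-c2ccccc2)ccc1=O`: 68.2%
Compound 2 `N=C(S)CCn1ncccc1=O`: 28.8%
Compound 3 `C/N=C(\S)CCn1ncccc1=O`: 35.7%

In a functional assay on the whole organism (stomach) for inhibition, with Rattus norvegicus as the target, at a dose of 100 mg/kg by the intraduodenal route (on this read-out lower numbers stand for less inhibition and higher numbers for more inhibition at the one dose given (going by the name of the read-out)), compound 1 gives the highest of the three numbers. The step of a number 32.5 percentage points lower from compound 1 to compound 3 (beyond the scatter) came with hydrogen in place of phenyl on an aromatic carbon, and compound 2 sits lower still, beyond the scatter from compound 1. Compound 4 `CCOC(=O)CCn1nc(-c2ccccc2)ccc1=O` keeps the phenyl of compound 1 and differs from it by a group of 5 heavy atoms (3 carbon, 2 oxygen; no ring) in place of a group of 4 heavy atoms (2 carbon, 1 nitrogen, 1 sulfur; no ring), on a saturated chain carbon, two bonds along the chain from an aromatic nitrogen. Within the data shown here, no measured step tests this replacement. Among the measured compounds shown here, the only step at the same place, a number 6.9 percentage points higher from compound 2 to compound 3 (within the scatter), was a far smaller change and stayed within the scatter, so it offers little guidance; here the whole group is exchanged. Compound 4 is therefore expected to show a step of a number 23.2 percentage points lower from compound 1 to compound 4 (beyond the scatter), with wide uncertainty. Compound 4 is estimated at 45%, within a range from 15% to 75%.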

Compound 4, a percentage reported as inhibition, in the whole organism at one dose (the size of the read-out at that dose, not a potency): 6.3%
Beside the measured number, compound 4's estimate is 38.7 percentage points above it; the measured number lies below the stated range.
By their numbers in this assay, from the lowest: compound 4; then compounds 2 and 3 (each within the scatter of the next); then compound 1.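

In this assay, ethoxycarbonyl in place of the sulfur-bearing group gives a number 61.9 percentage points lower from compound 1 to compound 4 (beyond the scatter) with the phenyl kept, so phenyl alone does not secure a high number. The earlier step at this place stayed within the scatter; this one shows that the read-out can depend heavily on the group on this saturated chain carbon. Nothing available explains why this exchange has such a large effect.

From the compounds shown here alone, it remains open which part of the sulfur-bearing group matters. A carboxylic acid or an amide at this place, or a longer chain carrying the group of compound 1, could help to separate those parts.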